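The source may report more compounds than this note shows. Statements on the series, on what has been measured and on what is new or still open speak of the compounds shown alone.

Measured compounds:
Compound 1 `CC[C@H](NC(C)=O)c1cc(Cl)ccc1C1CCN(C(=O)[C@H]2CN(C(C)(C)C)C[C@@H]2c2ccc(F)cc2F)CC1` gives 565 nM in a functional assay on CHO cells for agonist activity at Melanocortin receptor 4 (Homo sapiens), read by cAMP accumulation; a higher number here means that more compound is needed for the effect, a lower number that less compound is needed.
Compound 2 `CC[C@H](NC(C)=O)c1cc(Cl)ccc1C1CCN(C(=O)[C@@H]2CN(C(C)(C)C)C[C@H]2c2ccc(Cl)cc2Cl)CC1` gives 156 nM in this assay.

Compound 2 has the lower of the two numbers shown; its nearest neighbour is compound 1, whose number is higher by a margin that lies beyond the usual scatter. Going by the values given here, compound 1 and compound 2 differ in two places on the same aromatic ring, so their values show only what the pair shows, and no single step is isolated between them.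

Compound 3 `CC[C@H](NC(C)=O)c1cc(Cl)ccc1C1CCN(C(=O)[C@@H]2CN(C(C)(C)C)C[C@H]2c2ccc(Cl)cc2F)CC1` is compound 2 with one change: fluoro in place of chloro on an aromatic carbon. With this change compound 3 stands midway, in its substitution of that ring, between compound 2 and compound 1. Among the compounds with values here, no measured pair isolates this change, so its size is uncertain. Since compound 1, which carries two fluoro groups on that ring, has the higher number, the expected step is a 1.9-fold higher number from compound 2 to compound 3 (0.28 log units; within the scatter), a modest rise in the number that covers part of the gap to compound 1, and this expectation rests on two compounds alone. Compound 3 is therefore estimated at 300 nM, with a range from 150 nM to 650 nM.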

Compound 3, half-maximal effective concentration: 2.8 nM
For compound 3 the middle estimate is 110-fold (2.03 log units) above the measured one; the measured number lies below the stated range.
By their numbers in this assay, from the lowest: compound 3; then compound 2; then compound 1.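

In this assay, the change from 2,4-dichlorophenyl to 4-chloro-2-fluorophenyl isolates one substitution, fluoro in place of chloro on an aromatic carbon ortho to a large group and meta to a chloro group, and it gives a 56-fold lower number from compound 2 to compound 3 (1.75 log units; beyond the scatter) with the rest of the structure unchanged. Going by these compounds alone, this position is therefore highly sensitive to which of these two halogens it carries, something the earlier pair could not show, since those compounds differ in two places on the ring and isolate no single step. The data offer no measured explanation for the size of this step.

The compounds shown leave open whether other groups at this position, such as hydrogen, methyl, methoxy or nitrile, would give a number closer to that of the fluoro compound or the chloro compound. They also leave open whether the same swap would have a similar effect with another group at the chloro position meta to it, such as bromo or trifluoromethyl, or in a compound with a different amide side chain.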